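The source may hold more compounds than are shown below. What is called first, only, known or untested is meant among the compounds shown, and "the series" means these compounds.

Within the data shown here, compound 2 `CC(C)COc1nc(C(F)(F)Cl)ccc1CNC(=O)C(C)c1ccc(NS(C)(=O)=O)c(F)c1` stands with the higher of the two numbers so far in an assay on CHO cells for antagonist activity at transient receptor potential cation channel subfamily V member 1 (Homo sapiens), read by FLIPR (a higher number here means a weaker inhibitor, a lower number a stronger inhibitor), where compound 2 gives 0.6 nM; compound 1 `CC1CCN(c2nc(C(F)(F)Cl)ccc2CNC(=O)C(C)c2ccc(NS(C)(=O)=O)c(F)c2)CC1`, which in this assay gives 0.3 nM, sits a 2.0-fold higher number from compound 1 to compound 2 (0.30 log units; within the scatter). Compound 3 `CC(C(=O)NCc1ccc(C(F)(F)Cl)nc1OCc1ccccc1)c1ccc(NS(C)(=O)=O)c(F)c1` differs from compound 2 by phenyl in place of isopropyl on a saturated chain carbon bound to an oxygen on an aromatic ring. Among the measured compounds shown here, no measured step touches the chain end beyond the ring oxygen; the only step seen, from isobutoxy to a ring amine, stayed within the scatter, so nothing points to a large shift. Compound 3 is therefore estimated at 0.8 nM, range 0.3 nM to 2.5 nM, the expected step being a 1.3-fold higher number from compound 2 to compound 3 (0.12 log units; within the scatter).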

Compound 3, inhibition constant: 0.9 nM
Beside the measured number, compound 3's estimate is 1.1-fold (0.05 log units) below it, within the range that was stated.
By their numbers in this assay, from the lowest: compounds 1, 2 and 3 (each within the scatter of the next, the first and the last beyond it).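

In this assay, the chain end beyond the ring oxygen accepts phenyl in place of isopropyl with no readable shift (a 1.5-fold higher number from compound 2 to compound 3 (0.18 log units; within the scatter)), so a six-membered aromatic ring is tolerated there. Against the 4-methylpiperidin-1-yl group, benzyloxy gives the first step in the series to pass the scatter, and only modestly (a 3.0-fold higher number from compound 1 to compound 3 (0.48 log units; beyond the scatter)). No evidence is available that bears on either step.

Open, from the compounds shown here alone, is whether an amine or a carboxylic acid at the chain end keeps the number at this level. Also open, going by these compounds, is how a longer chain, such as phenethoxy, behaves on the same ring oxygen.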